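Sulfonamide series: expectation for a methoxyphenyl analogue

The source may report more compounds than this note shows. Statements on the series, on what has been measured and on what is new or still open speak of the compounds shown alone.

compound 1 `CCCCc1ccc(NS(=O)(=O)c2ccc(N3CCNC3=O)cc2)cc1`: 450 nM
compound 2 `CCc1cccc(NS(=O)(=O)c2ccc(N3CCNC3=O)cc2)c1`: 82 nM
compound 3 `O=C1NCCN1c1ccc(S(=O)(=O)Nc2cccc(Oc3ccccc3)c2)cc1`: 83 nM

In a functional assay on M21 cells (Homo sapiens) for antiproliferative activity, read by sulforhodamine B assay, with a stated time of 48 h (a higher number here means a weaker inhibitor, a lower number a stronger inhibitor), compound 2 gives the lowest number of the three, with compound 3 within the scatter of it and compound 1 a higher number beyond the scatter. Among the measured compounds shown here, compound 4 `COc1ccccc1NS(=O)(=O)c1ccc(N2CCNC2=O)cc1` has not yet been measured. 2-methoxyphenyl in place of 3-ethylphenyl on a sulfonamide nitrogen The only measured single-point step, a 1.0-fold higher number from compound 2 to compound 3 (0.01 log units; within the scatter), keeps the same position of substitution and does not involve 2-methoxyphenyl, so no measured step bears directly on this change; compound 1 shows only that a differently substituted phenyl can give a higher number. Compound 4 is therefore expected to give a somewhat higher number, a 2.4-fold higher number from compound 2 to compound 4 (0.39 log units; beyond the scatter), with wide uncertainty. The estimate for compound 4 is 200 nM, between 60 nM and 700 nM.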

Compound 4, half-maximal inhibitory concentration: 300 nM
Estimate against measurement, compound 4: 1.5-fold (0.18 log units) below, within the range that was stated.
By their numbers in this assay, from the lowest: compounds 2 and 3 (each within the scatter of the next); then compounds 4 and 1 (each within the scatter of the next).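

In this assay, the change from 3-ethylphenyl to 2-methoxyphenyl on the sulfonamide nitrogen gives a 3.7-fold higher number from compound 2 to compound 4 (0.56 log units; beyond the scatter), so this place does respond to the group it carries. The replacement keeps the count of heavy atoms and adds one hydrogen-bond acceptor, yet, unlike the phenoxy step, it moves the number beyond the scatter. Nothing shown accounts for this difference. The step alters both the substituent and its place on the phenyl ring, and these remain unseparated. As far as these compounds go, how an amine or a carboxylic acid on that ring would read also stays open.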